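Extending the chain on compound 2's imine nitrogen

The source may hold more compounds than are shown below. What is called first, only, known or untested is meant among the compounds shown, and "the series" means these compounds.

Measured compounds in an assay on DDT1 cells (Cricetulus griseus) for binding affinity to adenosine receptor A1 (Homo sapiens), read by radioligand binding; on this read-out lower numbers stand for stronger inhibition and higher numbers for weaker inhibition:
- compound 1, `C/N=C(\S)OC[C@H]1OC(n2cnc3c(NC4CCOC4)nc(Cl)nc32)[C@H](O)[C@@H]1O`, gives 71 nM
- compound 2, `CC/N=C(\S)OC[C@H]1OC(n2cnc3c(NC4CCOC4)ncnc32)[C@H](O)[C@@H]1O`, gives 33 nM
- compound 3, `CC/N=C(\S)OC[C@H]1OC(n2cnc3c(NC4CCOC4)nc(Cl)nc32)[C@H](O)[C@@H]1O`, gives 55 nM

Compound 2 shows the lowest of the three numbers. Its nearest neighbour is compound 3, reached by a 1.7-fold higher number from compound 2 to compound 3 (0.22 log units; within the scatter), a step within the scatter; compound 1 lies further off, and the gap between compound 2 and compound 1 is beyond the scatter. The unmeasured compound 4, `CCCC/N=C(\S)OC[C@H]1OC(n2cnc3c(NC4CCOC4)ncnc32)[C@H](O)[C@@H]1O`, is compound 2 with ethyl in place of hydrogen on a saturated chain carbon, two bonds along the chain from a double-bonded nitrogen; cut one bond further out, the same change reads methyl to propyl.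

Going by the values given here, only one measured step touches the same chain: a 1.3-fold lower number from compound 1 to compound 3 (0.11 log units; within the scatter), where methyl replaced hydrogen on the chain carbon bound to the double-bonded nitrogen, and that step stayed within the scatter. Among the compounds with values here, no measured pair shows a longer chain at this place, so the effect of growing from methyl to propyl is not covered directly. On this basis, the step from compound 2 to compound 4 is expected to be small, as a 1.1-fold lower number from compound 2 to compound 4 (0.04 log units; within the scatter), with no clear direction beyond the scatter. Compound 4 is therefore estimated at 30 nM in this assay, with a range from 12 nM to 80 nM.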

Compound 4, inhibition constant: 157 nM
Beside the measured number, compound 4's estimate is 5.2-fold (0.72 log units) below it, and the stated range ends below it.
By their numbers in this assay, from the lowest: compounds 2, 3 and 1 (each within the scatter of the next, the first and the last beyond it); then compound 4.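

In this assay, going by these compounds alone, the ethyl to butyl change on the chain at the double-bonded nitrogen gives a 4.8-fold higher number from compound 2 to compound 4 (0.68 log units; beyond the scatter), the first step on this chain that lies beyond the scatter. Within the data shown here, the only earlier step on this chain, a 1.3-fold lower number from compound 1 to compound 3 (0.11 log units; within the scatter), stayed within the scatter, so this position is not indifferent to chain length: adding ethyl two bonds along the chain moves the number towards weaker inhibition, a change that a single added methyl did not reveal. Nothing at hand gives a reason for this step.

The compounds shown leave open whether the shift already appears with a propyl chain on the nitrogen or only with butyl, and whether a pentyl chain or a branched isopropyl group would go further in the same direction. They also leave open whether butyl acts the same way with chloro on the aromatic carbon, since the earlier chain step was read with chloro present, while the chloro step itself, a 1.7-fold higher number from compound 2 to compound 3 (0.22 log units; within the scatter), was read with ethyl and stayed within the scatter.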